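Side-Chain Exchange on a Shared Core: Expectation for Compound 4

The source may hold more compounds than are shown below. What is called first, only, known or untested is meant among the compounds shown, and "the series" means these compounds.

Measured in a functional assay; a lower number here means a stronger inhibitor, a higher number a weaker inhibitor:
Compound 1 `CC(C)C[C@@H]1NC(=O)[C@H](CS)NC1=O` gives 100000 nM
Compound 2 `CC(C)C[C@@H]1NC(=O)[C@H](CCC(=O)O)NC1=O` gives 80000 nM
Compound 3 `CC(C)C[C@@H]1NC(=O)[C@H](CCCCN)NC1=O` gives 160000 nM

Compound 3 stands highest of these three numbers, yet the steps leading to it, a 1.6-fold higher number from compound 1 to compound 3 (0.20 log units; within the scatter) and a 2.0-fold higher number from compound 2 to compound 3 (0.30 log units; within the scatter), both lie within the scatter; the remaining step, a 1.3-fold lower number from compound 1 to compound 2 (0.10 log units; within the scatter), is also within the scatter. Compound 4 `CC(C)C[C@@H]1NC(=O)[C@H](CC(N)=O)NC1=O` differs from compound 3 by carbamoyl in place of 3-aminopropyl on a saturated chain carbon bound to a saturated ring carbon. Every measured step exchanged the side chain at this same place on the shared core, and none moved the number beyond the scatter, so no step beyond the scatter is expected in this assay here either. Compound 4 is therefore estimated at 100000 nM, within 40000 nM to 250000 nM. The expected step is a 1.6-fold lower number from compound 3 to compound 4 (0.20 log units; within the scatter).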

Compound 4, half-maximal inhibitory concentration: 170000 nM
Compound 4: the middle estimate sits 1.7-fold (0.23 log units) below what was measured, and the stated range covers the measured number.
By their numbers in this assay, from the lowest: compounds 2, 1, 3 and 4 (each within the scatter of the next, the first and the last beyond it).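

In this assay, among the compounds shown here, carbamoyl in place of carboxymethyl gives the first step at this place on the shared core to pass the scatter (a 2.1-fold higher number from compound 2 to compound 4 (0.33 log units; beyond the scatter)), though only modestly. The other two new steps (a 1.1-fold higher number from compound 3 to compound 4 (0.03 log units; within the scatter) and a 1.7-fold higher number from compound 1 to compound 4 (0.23 log units; within the scatter)) stay within it, so compound 4 cannot be told apart from compound 1 or compound 3. No supporting data bear on this result. Going by these compounds, whether a side chain carrying a phenyl ring or a guanidine would move the number further at this same place remains open.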